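The source may hold more compounds than are shown below. What is called first, only, known or untested is meant among the compounds shown, and "the series" means these compounds.

Measured in an assay on isolated protein for inhibition of Ectonucleotide pyrophosphatase/phosphodiesterase family member 1 (Homo sapiens), tested at 10 uM; a lower number here means less inhibition, a higher number more inhibition at the concentration tested (going by the name of the read-out):

Compound 1, `O=C(CSc1nc2cccnc2[nH]1)Nc1ccccc1Cl`, gives 19%.
Compound 2, `CN(C)c1ccc(NC(=O)CSc2nc3cccnc3[nH]2)cc1`, gives 23%.
Compound 3, `O=C(CSc1nc2cccnc2[nH]1)Nc1ccc(Cl)cc1`, gives 17%.

All three compounds share the same core and differ only in the group on the amide-type nitrogen. Compound 3 sits at the low end of these three numbers, yet neither of its steps separates it from the others: the step of a number 2 percentage points lower from compound 1 to compound 3 (within the scatter) and the step of a number 6 percentage points lower from compound 2 to compound 3 (within the scatter) are both within the scatter, so the three numbers cannot be told apart.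

Compound 4, `COc1ccc(NC(=O)CSc2nc3cccnc3[nH]2)cc1`, differs from compound 3 by methoxy in place of chloro on an aromatic carbon. Within the data shown here, the step that bears most on this change is the one from compound 2 to compound 3, where a different group on the same aromatic carbon was exchanged for chloro and the number moved a number 6 percentage points lower from compound 2 to compound 3 (within the scatter), which is within the scatter. The step of a number 2 percentage points lower from compound 1 to compound 3 (within the scatter), which only shifts the chloro to another position on that ring, also stayed within the scatter. Among the measured compounds shown here, nothing measured so far suggests that a swap at this carbon moves the read-out beyond the scatter, so the expected step of a number 3 percentage points higher from compound 3 to compound 4 (within the scatter) is essentially none. Compound 4 is therefore estimated at 20%, with a likely range from 10% to 30%.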

Compound 4, a percentage reported as inhibition, at one concentration (the size of the read-out at that concentration, not a potency): 48%
Beside the measured number, compound 4's estimate is 28 percentage points below it; the whole stated range lies below it.
By their numbers in this assay, from the lowest: compounds 3, 1 and 2 (each within the scatter of the next); then compound 4.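

In this assay, among these compounds, the group on this aromatic carbon, para to a large group, turns out to matter: methoxy in place of chloro gives a number 31 percentage points higher from compound 3 to compound 4 (beyond the scatter) and is a step that clears the scatter, which no step among the earlier compounds did. Methoxy in place of dimethylamino on the same carbon gives a number 25 percentage points higher from compound 2 to compound 4 (beyond the scatter) as well, so compound 4 stands apart from both of the other groups tried there, and the flat picture from the first three compounds does not hold for every group at this carbon. Nothing available explains why methoxy behaves differently from chloro and dimethylamino here.

The compounds shown leave open whether the rise belongs to the oxygen or to the methyl attached to it, which a hydroxyl or a plain methyl on the same carbon could help separate, and whether a longer chain such as ethoxy would keep the higher number. They also leave open whether methoxy would do the same at the ring position where compound 1 carries its chloro, and how potent compound 4 is, since its read-out comes from one concentration.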